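A Bromo for Methyl on the Benzyl Hydroxamic Acid

The source may report more compounds than this note shows. Statements on the series, on what has been measured and on what is new or still open speak of the compounds shown alone.

Results in a functional assay on HCT-15 cells (Homo sapiens) for inhibition, read by sulforhodamine B assay; a lower number here means a stronger inhibitor of growth, a higher number a weaker inhibitor of growth:
- compound 1 `COc1ccccc1CN1CCC=C(CCC(=O)NO)C1=O` gives > 10000 nM (a limit, not a number)
- compound 2 `Cc1ccc(CN2CCC=C(CCC(=O)NO)C2=O)cc1` gives 8510 nM
- compound 3 `O=C(CCC1=CCCN(Cc2ccc3ccccc3c2)C1=O)NO` gives "not determined" (no result reported)

Within the data shown here, compound 2 holds the only true number in this small set, so it has no second number to be ranked against. Compound 1 offers only a limit, and compound 3 has no result.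

The next compound to be tested is compound 4 `O=C(CCC1=CCCN(Cc2ccc(Br)cc2)C1=O)NO`. It differs from compound 2 by one swap (bromo in place of methyl on an aromatic carbon), with bromo in place of methyl on an aromatic carbon, para to a large group, so that 4-methylphenyl becomes 4-bromophenyl.

Among the measured compounds shown here, no measured pair shows what a single change does here, so the expectation rests on compound 2 at 8510 nM and on the modest size of this swap. The expected step of a 1.3-fold lower number from compound 2 to compound 4 (0.12 log units; within the scatter) is small, probably no larger than the scatter, with a slight lean towards stronger inhibition. In this assay compound 4 is estimated at 6500 nM, with an expected range from 2500 nM to 14000 nM.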

Compound 4, concentration for 50% growth inhibition: 1720 nM
Compound 4: middle estimate off by 3.8-fold (0.58 log units), on the high side, and the stated range ends above it.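

In this assay, among these compounds, the change from 4-methylphenyl to 4-bromophenyl gives the first readable step: a 4.9-fold lower number from compound 2 to compound 4 (0.69 log units; beyond the scatter). It shows that this place on the aromatic ring, para to a large group, is not indifferent, since exchanging one heavy atom for another, with no ring, hydrogen-bond donor or hydrogen-bond acceptor added or lost, is enough to shift growth inhibition beyond the scatter towards the stronger side. Compound 1 still offers only a limit and gives no second step: the limit of > 10000 nM in this assay, at which 1 of the 4 values shown sits.

On these data alone, whether chloro, trifluoromethyl or an amine in the same place would match bromo remains open, so one step cannot show whether the shift is particular to bromo. Also open, as far as these compounds go, is how a longer chain leading to the hydroxamic acid would alter the value of compound 4.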